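The compounds below may be only part of what the source reports. "The series", "measured", "known", "first", "only" and "open" are said of these compounds alone.

Compound 1 `COc1ccc(-c2cc(=O)c3c(OC)cc(OC)cc3n2S(=O)(=O)c2ccc(C=O)cc2)cc1` — > 34400 nM
Compound 2 `COc1ccc(-c2cc(=O)c3c(OC)cc(OC)cc3n2S(=O)(=O)c2ccc(C#N)cc2)cc1` — > 17200 nM

In a functional assay on HepG2 cells (Homo sapiens) for antiproliferative activity, with a stated time of 72 h (a higher number here means that more compound is needed for the effect, a lower number that less compound is needed), compound 1 gives > 34400 nM, which is a limit of the assay rather than a number. Compound 2 gives > 17200 nM, again a limit. The step that the two limits leave unreadable from compound 1 to compound 2 therefore stays unreadable, as the two limits the limit of > 17200 nM in this assay, at which 1 of the 2 values shown sits, and the limit of > 34400 nM in this assay, at which 1 of the 2 values shown sits, show. Compound 3 (`COc1ccc(-c2cc(=O)c3c(OC)cc(OC)cc3n2S(=O)(=O)c2c(F)c(F)c(F)c(F)c2F)cc1`) carries a further change at the sulfonyl sulfur: 2,3,4,5,6-pentafluorophenyl in place of 4-cyanophenyl on a sulfonyl sulfur. Among the compounds with values here, no measured step bears on this change, and both measured values sit at limits. Compound 3 is expected to remain at a limit as well, so the step that the limit leaves unreadable from compound 2 to compound 3 is estimated to show no readable change. For compound 3 the estimate is 30000 nM, between 8000 nM and 100000 nM.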

Compound 3, half-maximal effective concentration: > 34400 nM
Compound 3 ended at the assay's limit; the forecaster's own chance of this, stated with the estimate: 75%; middle value at least 1.1-fold (0.05 log units) away from the limit.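

Within the data shown here, compound 1, compound 2 and compound 3 all sit at limits of the assay, and no step between them can be read. The compounds shown leave open whether these groups on the sulfonyl sulfur differ at all in this assay.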